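Ether chain variation on the shared core

The source may report more compounds than this note shows. Statements on the series, on what has been measured and on what is new or still open speak of the compounds shown alone.

Measured in a functional assay on DLD-1 cells (Homo sapiens) for cytotoxicity, read by MTT assay, with a stated time of 48 h (on this read-out lower numbers stand for stronger inhibition and higher numbers for weaker inhibition), so far:
compound 1, `CCCCOc1ccc2c(Cl)ccnc2c1`: 3780 nM
compound 2, `CCCCCCOc1ccc2c(Cl)ccnc2c1`: 2660 nM
compound 3, `CCOc1ccc2c(Cl)ccnc2c1`: 2750 nM

All three numbers sit close together. Compound 3 stands second highest of the three; its nearest neighbour is compound 2, with a 1.0-fold higher number from compound 2 to compound 3 (0.01 log units; within the scatter), and its furthest is compound 1, with a 1.4-fold lower number from compound 1 to compound 3 (0.14 log units; within the scatter). Lengthening the chain at the far end likewise moved little: a 1.4-fold lower number from compound 1 to compound 2 (0.15 log units; within the scatter). None of these steps leaves the scatter, so on the data in hand the ether chain can be shortened or extended without any resolvable effect in this assay.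

Compound 4, `Clc1ccnc2cc(OCCCc3ccccc3)ccc12`, carries a larger change at the same position: benzyl in place of hydrogen on a saturated chain carbon, two bonds along the chain from an oxygen on an aromatic ring. Among the measured compounds shown here, the steps that bear on it are those at the chain carbon two bonds from the ring oxygen and along the chain, all of which were flat. A benzyl is a bigger addition than any tried so far, but nothing measured points in either direction, so the expected step is none beyond the scatter, a 1.1-fold lower number from compound 3 to compound 4 (0.04 log units; within the scatter). Compound 4 is therefore estimated at 2500 nM, with a range from 1000 nM to 6500 nM, pending the measurement.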

Compound 4, half-maximal inhibitory concentration: 2140 nM
Beside the measured number, compound 4's estimate is 1.2-fold (0.07 log units) above it; measured number inside the range.
By their numbers in this assay, from the lowest: compounds 4, 2, 3 and 1 (each within the scatter of the next).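

Benzyl in place of hydrogen on a saturated chain carbon, two bonds along the chain from an oxygen on an aromatic ring, gives in this assay a 1.3-fold lower number from compound 3 to compound 4 (0.11 log units; within the scatter) and so shows that this position accepts a chain ending in a six-membered aromatic ring of carbon only with no resolvable effect, which the purely saturated chains of compounds 1, 2 and 3 could not show. The same holds against both other chains, with a 1.2-fold lower number from compound 2 to compound 4 (0.09 log units; within the scatter) and with a 1.8-fold lower number from compound 1 to compound 4 (0.25 log units; within the scatter) as the widest of the three new steps, so phenyl at the chain end cannot be told apart from propyl or methyl there. No measurement available on these compounds offers an explanation for this flat behaviour.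

Still open, going by these compounds, is whether a group of another kind at the end of the chain, such as an amine or a carboxylic acid, or a much longer chain, would move the number beyond the scatter. Also open, on these data alone, is whether a change to the shared core, rather than to the ether chain, would give a step that can be resolved in this assay at all.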